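The source may hold more compounds than are shown below. What is called first, only, known or untested is meant among the compounds shown, and "the series" means these compounds.

Compound 1 `COc1cc2c(Oc3ccc(NC(=O)c4cc(-c5ccc(C(F)(F)F)cc5)ccn4)cc3F)ccnc2cc1OCCCN1CCCCC1` and compound 2 `COc1cc2c(Oc3ccc(NC(=O)c4cc(-c5ccc(C(F)(F)F)cc5)ccn4)cc3F)ccnc2cc1OCCCN1CCCC1` share one core, while compound 3 `COc1cc2c(Oc3ccc(NC(=O)c4nccc(-c5ccccc5)n4)cc3F)ccnc2cc1OCCCN1CCCCC1` and compound 4 `COc1cc2c(Oc3ccc(NC(=O)c4nccc(-c5ccccc5)n4)cc3F)ccnc2cc1OCCCN1CCCC1` share another; how the two cores differ is not broken down here. In a functional assay on HT-29 cells (Homo sapiens) for cytotoxicity, read by MTT assay, with a stated time of 72 h (a lower number here means a stronger inhibitor, a higher number a weaker inhibitor), compound 1 gives 230 nM, and compound 2 gives 720 nM. In this assay compound 3 gives 260 nM. The change from compound 1 to compound 2 is pyrrolidin-1-yl in place of piperidin-1-yl on a saturated chain carbon, three bonds along the chain from an oxygen on an aromatic ring, and it produced a 3.1-fold higher number from compound 1 to compound 2 (0.50 log units; beyond the scatter). Compound 4 carries the same change on the other core, namely (pyrrolidin-1-yl in place of piperidin-1-yl on a saturated chain carbon, three bonds along the chain from an oxygen on an aromatic ring). The step from compound 3 to compound 4 is expected to be a 3.1-fold higher number from compound 3 to compound 4 (0.49 log units; beyond the scatter), resting on the earlier step of a 3.1-fold higher number from compound 1 to compound 2 (0.50 log units; beyond the scatter) seen once on the first core. Compound 4 is therefore estimated at 800 nM, somewhere between 350 nM and 1800 nM.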

Compound 4, half-maximal inhibitory concentration: 390 nM
For compound 4 the middle estimate is 2.1-fold (0.31 log units) above the measured one; the range from low to high includes it.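

In this assay, replacing piperidin-1-yl with pyrrolidin-1-yl on the core of compound 3 gives a 1.5-fold higher number from compound 3 to compound 4 (0.18 log units; within the scatter), so on this core alone the change cannot be told apart from ordinary repeat-to-repeat variation. Set beside the step on the first core, the two results cannot be told apart either: the same change on two cores in this assay, a 3.1-fold higher number (0.50 log units; beyond the scatter) from compound 1 to compound 2 and a 1.5-fold higher number (0.18 log units; within the scatter) from compound 3 to compound 4, 2.1-fold (0.32 log units) apart, within the scatter of two such steps. This is compatible with the change carrying over between these two cores, but it does not prove that the effect has the same size on both, and one pair per core gives no rule for other cores.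

As far as these compounds go, whether another amine in place of piperidin-1-yl, such as morpholine or dimethylamine, would behave alike stays open. So does the effect of a longer chain.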